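The source may report more compounds than this note shows. Statements on the series, on what has been measured and on what is new or still open speak of the compounds shown alone.

Of the compounds shown here, three on a shared core have been measured. In an assay on CHO cells for displacement of a labelled ligand from adenosine receptor A1 (Homo sapiens), read by scintillation counting, with a stated time of 3 h (a higher number here means a weaker inhibitor, a lower number a stronger inhibitor), compound 1 `Cc1ccc(-c2nc(N)c3nc(-c4ccccc4)sc3n2)o1` gives 28.9 nM. Compound 2 `COc1cccc(-c2nc(N)c3nc(-c4ccco4)sc3n2)c1` gives 62.3 nM in this assay, and compound 3 `Nc1nc(-c2cccc(O)c2)nc2sc(-c3ccco3)nc12` gives 51 nM. For the measured compounds named here, the only single-point step among them, a 1.2-fold lower number from compound 2 to compound 3 (0.09 log units; within the scatter), stays within the scatter. Compound 3 thus stands second highest of the three numbers, nearest to compound 2 and furthest from compound 1, both gaps within the scatter. Compound 4 `Cc1ccc(-c2nc(N)c3nc(-c4ccco4)sc3n2)o1` differs from compound 3 by 5-methylfuran-2-yl in place of 3-hydroxyphenyl on an aromatic carbon. Going by the values given here, no measured step bears directly on this change; compound 1 carries the same 5-methylfuran-2-yl group yet differs from compound 4 elsewhere, and its number and that of compound 3 lie within the scatter of each other. Compound 4 is therefore expected to show a 1.5-fold lower number from compound 3 to compound 4 (0.16 log units; within the scatter), no shift beyond the scatter. The estimate for compound 4 is 35 nM, with a range from 12 nM to 100 nM.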

Compound 4, inhibition constant: 45.9 nM
The estimate for compound 4 lay 1.3-fold (0.12 log units) below the measured number; low and high end bracket the measured number.
By their numbers in this assay, from the lowest: compounds 1, 4, 3 and 2 (each within the scatter of the next, the first and the last beyond it).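

In this assay, 5-methylfuran-2-yl in place of 3-hydroxyphenyl, on the aromatic carbon between two ring nitrogen atoms, gives a 1.1-fold lower number from compound 3 to compound 4 (0.05 log units; within the scatter), so this position accepts a five-membered aromatic ring without the hydrogen-bond donor and with no shift beyond the scatter. With that group held in place, furan-2-yl in place of phenyl on an aromatic carbon gives a 1.6-fold higher number from compound 1 to compound 4 (0.20 log units; within the scatter), again no shift beyond the scatter. Nothing available gives a reason for these results. Open, on these data alone, is whether an amine, a carboxylic acid or a longer chain at this position would move the number beyond the scatter.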